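This account rests on a few compounds, and the source may have more. Where it says the series, first, only, none or still open, it means among the compounds named here.

Working notes on the series built on the shared core of compound 1 `O=[N+]([O-])c1cccc(CNc2cc(C(F)(F)F)cc3[nH]ncc23)c1`. In an assay for inhibition of Tryptophan 2,3-dioxygenase (Homo sapiens), with stated times of 10 min and 60 min, tested at 100 uM (a higher number here means a stronger effect of the compound at the concentration tested, a lower number a weaker effect), compound 1 gives 82%. Compound 2 `FC(F)(F)c1cccc(CNc2cc(C(F)(F)F)cc3[nH]ncc23)c1` carries trifluoromethyl in place of nitro on an aromatic carbon; in this assay compound 2 gives 74%, and the step of a number 8 percentage points lower from compound 1 to compound 2 (within the scatter) stays within the scatter. Compound 3 `O=C(O)c1cccc(CNc2cc(C(F)(F)F)cc3[nH]ncc23)c1` carries carboxy in place of nitro on an aromatic carbon; in this assay compound 3 gives 94%. Compound 3 stands highest of the three: the steps of a number 12 percentage points higher from compound 1 to compound 3 (beyond the scatter) and a number 20 percentage points higher from compound 2 to compound 3 (beyond the scatter) are both beyond the scatter, though modest in size.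

Compound 4 `CNC(=O)c1cccc(CNc2cc(C(F)(F)F)cc3[nH]ncc23)c1` differs from compound 3 by methylamino in place of hydroxy on a carbonyl carbon. Among the measured compounds shown here, none of the measured steps touches the carbonyl carbon; each of them exchanges the whole group on the aromatic carbon, so there is no direct precedent in this assay for the move from carboxy to methylcarbamoyl. What the measured values do show is that all three compounds sit in a fairly narrow band, with compound 3 at the top of it. The expected step of a number 9 percentage points lower from compound 3 to compound 4 (within the scatter) is therefore small, on the downward side if anything, and may well fall within the scatter. Compound 4 is estimated at 85%, with a range from 65% to 98%.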

Compound 4, a percentage reported as inhibition, at one concentration (the size of the read-out at that concentration, not a potency): 91%
Estimate against measurement, compound 4: 6 percentage points below, and the stated range covers the measured number.
By their numbers in this assay, from the lowest: compounds 2, 1, 4 and 3 (each within the scatter of the next, the first and the last beyond it).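

In this assay, the step of a number 3 percentage points lower from compound 3 to compound 4 (within the scatter) shows that the carbonyl carbon accepts methylamino in place of hydroxy with no change that can be told from the scatter, so the carboxy group can give way to methylcarbamoyl in this series. Measured against the other groups on the aromatic carbon, the step of a number 17 percentage points higher from compound 2 to compound 4 (beyond the scatter) keeps the separation from trifluoromethyl already seen with carboxy, whereas the step of a number 9 percentage points higher from compound 1 to compound 4 (within the scatter) does not reproduce the separation from nitro that carboxy gave. Nothing available bears on the reason for this result.

The compounds shown leave open how the carbonyl carbon responds to amino, dimethylamino or a longer chain such as ethylamino in place of methylamino, and whether the amide hydrogen is needed at all. They also leave open whether carboxy and methylcarbamoyl would separate on a true potency measure, as a read-out at one concentration gives no potency for compound 3 or compound 4.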